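Lengthening the Side Chain on a Benzylated Ketone

The compounds below may be only part of what the source reports. "The series", "measured", "known", "first", "only" and "open" are said of these compounds alone.

Measured compounds:
compound 1, `CCC[C@@H]1O[C@H](COCc2ccccc2)[C@@H](OCc2ccccc2)[C@H](OCc2ccccc2)[C@H]1O`, 38600 nM
compound 2, `C[C@@H]1O[C@H](COCc2ccccc2)[C@@H](OCc2ccccc2)[C@H](OCc2ccccc2)C1=O`, > 50000 nM

Compound 1 `CCC[C@@H]1O[C@H](COCc2ccccc2)[C@@H](OCc2ccccc2)[C@H](OCc2ccccc2)[C@H]1O` was tested in a functional assay on HOS cells (Homo sapiens) for antiproliferative activity, read by sulforhodamine B assay (a higher number here means a weaker inhibitor of growth, a lower number a stronger inhibitor of growth), and gives 38600 nM. For compound 2 `C[C@@H]1O[C@H](COCc2ccccc2)[C@@H](OCc2ccccc2)[C@H](OCc2ccccc2)C1=O` this assay reports only a limit, > 50000 nM; the value is one of the limits noted in this assay (the limit of > 50000 nM in this assay, at which 1 of the 2 values shown sits), not a number. Compound 3 `CCC[C@@H]1O[C@H](COCc2ccccc2)[C@@H](OCc2ccccc2)[C@H](OCc2ccccc2)C1=O` has not been measured; it differs from compound 2 by ethyl in place of hydrogen on a saturated chain carbon bound to a saturated ring carbon. Going by the values given here, no measured pair of compounds shows this change on its own, so its effect is unknown from these data. Compound 1, which carries the propyl chain, gives a weak value in this assay. The step from compound 2 to compound 3 is expected to be small or none beyond the scatter, an at least 1.1-fold lower number from compound 2 to compound 3 (0.04 log units; that floor lies within the scatter). Compound 3 is therefore estimated at 45000 nM, within a range from 15000 nM to 150000 nM, with a fair chance that this assay again reports only a limit.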

Compound 3, concentration for 50% growth inhibition: > 50000 nM
Compound 3: no number, only a limit (the forecaster's own chance of this, stated with the estimate: 55%); middle value at least 1.1-fold (0.04 log units) away from the limit.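

In this assay compound 2 and compound 3 are both reported only as limits, and the step between them cannot be read: the limit of > 50000 nM in this assay, at which 2 of the 3 values shown sit. The compounds shown leave open the size of any effect of ethyl in place of hydrogen on a saturated chain carbon bound to a saturated ring carbon.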